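Swapping Tert-Butyl for Fluoro: What to Expect

This account rests on a few compounds, and the source may have more. Where it says the series, first, only, none or still open, it means among the compounds named here.

Measured so far:
Compound 1, `CCc1ccccc1NC(=O)N[C@@H](C)c1ccccc1`: in an ADME assay on the whole organism with Oryza sativa as the target, tested at 0.1 uM (a higher number here means a weaker effect of the compound at the concentration tested, a lower number a stronger effect), compound 1 gives 100%.
Compound 2, `C[C@@H](NC(=O)Nc1ccc(C(C)(C)C)cc1)c1ccccc1`: compound 2 gives 100%.
Compound 3, `C[C@H](NC(=O)Nc1ccc(C(C)(C)C)cc1)c1ccccc1`: compound 3 gives 100%.

All three compounds sit at the same level, so compound 3 stands level with compounds 1 and 2, with no difference beyond the scatter to either. Among the compounds with values here, the only step between two measured compounds that differ in a single place is no change at the digits printed from compound 2 to compound 3 (within the scatter), and that is explained simply by the fact that compounds 2 and 3 differ only in the configuration as drawn.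

The next compound, compound 4, `C[C@H](NC(=O)Nc1ccc(F)cc1)c1ccccc1`, differs from compound 3 in one place: fluoro in place of tert-butyl on an aromatic carbon. Within the data shown here, no measured step involves a change of this kind; the one step available concerns configuration only and says nothing about replacing one group by another. Among the measured compounds shown here, what the data do show is that every compound so far, whatever its substituent, gives the same high reading.

On that basis compound 4 is expected to stay where compound 3 stands, with an expected step of no change at the digits printed from compound 3 to compound 4 (within the scatter). The estimate for compound 4 is 100%, within 85% to 100%.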

Compound 4, a percentage reported as activity, at one concentration (the size of the read-out at that concentration, not a potency): 96%
For compound 4 the middle estimate is 4 percentage points above the measured one; the range from low to high includes it.
By their numbers in this assay, from the lowest: compounds 4, 1, 2 and 3 (each within the scatter of the next).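

In this assay, putting fluoro in place of tert-butyl on the aromatic carbon gives a number 4 percentage points lower from compound 3 to compound 4 (within the scatter). Within the data shown here, this is the first step here that replaces one group with another, rather than changing only the configuration as drawn, and it shows that this position tolerates a large change in group size: tert-butyl has 4 heavy atoms and fluoro has 1, yet the reading stays within the scatter. Nothing available bears on why this swap leaves the reading within the scatter.

The compounds shown leave open whether any group on this aromatic carbon can move the reading beyond the scatter, for example an amine, a carboxylic acid or a longer chain. They also leave open whether the other configuration of the fluoro compound would read the same as compound 4.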